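Methoxy in Place of Fluoro: Expectation for Compound 4

The source may hold more compounds than are shown below. What is called first, only, known or untested is meant among the compounds shown, and "the series" means these compounds.

Three compounds were measured in a functional assay on the whole organism (strain C57BL/6) for inhibition, with Mus musculus as the target, read by paw edema, with stated times of 1 h and 4 h, at a dose of 100 mg/kg by the oral route; on this read-out lower numbers stand for less inhibition and higher numbers for more inhibition at the one dose given (going by the name of the read-out). Compound 1 `COc1ccccc1NC(=O)CCc1nc(Cc2ccc(NC(C)=O)cc2)no1` gives 87.7%, compound 2 `CC(=O)Nc1ccc(Cc2noc(CCC(=O)Nc3ccccc3F)n2)cc1` gives 67.1%, and compound 3 `COc1ccc(NC(=O)CCc2nc(Cc3ccc(NC(C)=O)cc3)no2)cc1F` gives 60.3%. The two cores of compound 2 and compound 3 differ by 3-fluoro-4-methoxyphenyl in place of 2-fluorophenyl on an amide-type nitrogen, and in this assay the step is a number 6.8 percentage points lower from compound 2 to compound 3 (within the scatter). Between compound 1 and compound 3 the step is a number 27.4 percentage points lower from compound 1 to compound 3 (beyond the scatter).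

The change of interest, (methoxy in place of fluoro on an aromatic carbon), produced a number 20.6 percentage points higher from compound 2 to compound 1 (beyond the scatter). The same kind of change leads from compound 3 to compound 4 `COc1ccc(NC(=O)CCc2nc(Cc3ccc(NC(C)=O)cc3)no2)cc1OC`, namely (methoxy in place of fluoro on an aromatic carbon). The surroundings are not the same: in compound 2 the fluoro sits ortho to a large group, whereas in compound 3 it sits ortho to a methoxy group and meta to a large group. Compound 4 is not yet measured in this assay.

Going by the values given here, because compound 2 to compound 1 gave a number 20.6 percentage points higher from compound 2 to compound 1 (beyond the scatter), compound 4 is expected to rise against compound 3, though the step is expected to be smaller, a number 11.7 percentage points higher from compound 3 to compound 4 (beyond the scatter), since the place of the change differs from the one measured and compound 3 stands lowest of the three. Compound 4 is therefore estimated at 72% in this assay, with a range from 55% to 88%.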

Compound 4, a percentage reported as inhibition, in the whole organism at one dose (the size of the read-out at that dose, not a potency): 95.9%
Compound 4: the middle estimate sits 23.9 percentage points below what was measured; measured number outside the range, above it.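

The new step, a number 35.6 percentage points higher from compound 3 to compound 4 (beyond the scatter), runs in the same direction as the earlier one in this assay, so methoxy in place of fluoro on an aromatic carbon gave a higher number on both cores, but the size of the step did not carry over: the same change on two cores in this assay, a number 20.6 percentage points higher (beyond the scatter) from compound 2 to compound 1 and a number 35.6 percentage points higher (beyond the scatter) from compound 3 to compound 4, 15 percentage points apart, beyond the scatter of two such steps

Set against the other two compounds, 3,4-dimethoxyphenyl in place of 2-fluorophenyl gives a number 28.8 percentage points higher from compound 2 to compound 4 (beyond the scatter), whereas 3,4-dimethoxyphenyl in place of 2-methoxyphenyl gives a number 8.2 percentage points higher from compound 1 to compound 4 (within the scatter), so compound 1 and compound 4 cannot be told apart at this one dose. These two pairs show only that the direction held across the cores shown; they do not show that it would hold on a further core, that the size of the step can be predicted from one core to another, or why the two steps differ.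

The compounds shown leave open whether another group on the same aromatic carbon, such as ethoxy, hydroxyl or an amine, would give a step like that of methoxy. They also leave open how the change would behave with a longer chain in place of the one that carries the amide.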